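The compounds below may be only part of what the source reports. "The series", "measured", "known", "first", "only" and "open" are said of these compounds alone.

In a physicochemical assay for solubility, read by nephelometry, at pH 2 (on this read-out higher numbers stand for higher solubility and lower numbers for lower solubility), compound 1, with the structure `Cc1cnc(NC(=O)CCCOc2cncc(Cl)c2)s1`, gives 1600 nM. Compound 2, with the structure `N#Cc1cnc(NC(=O)CCCOc2cccc(Cl)c2)s1`, is recorded in this assay only as a limit, < 1600 nM, rather than as a number. That reading sits at the line described by the limit of < 1600 nM in this assay, at which 1 of the 2 values shown sits, so the true solubility of compound 2 is not pinned down. Compound 3, with the structure `N#Cc1cnc(NC(=O)CCCOc2cccc(C(F)(F)F)c2)s1`, differs from compound 2 in one place: trifluoromethyl in place of chloro on an aromatic carbon. Within the data shown here, no pair of measured compounds shows what this exchange does in this assay, so nothing measured can guide the size of the step. Since compound 2 already rests at a limit, only a small shift is expected, a step that the limit leaves unreadable from compound 2 to compound 3, not beyond the usual scatter. Compound 3 is therefore expected to give about 900 nM in this assay, most likely between 250 nM and 2000 nM, and it may well return only a limit again.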

Compound 3, solubility: < 1600 nM
Compound 3 gave a limit, no number (the forecaster's own chance of this, stated with the estimate: 70%); the middle value does not contradict the limit.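

Compound 2 and compound 3 are both recorded in this assay only as limits, not numbers, so no step from one to the other can be read: the limit of < 1600 nM in this assay, at which 2 of the 3 values shown sit.

The compounds shown leave open how trifluoromethyl in place of chloro on an aromatic carbon changes the read-out in this assay.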